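The source may report more compounds than this note shows. Statements on the series, on what has been measured and on what is new or still open speak of the compounds shown alone.

Measured so far:
compound 1 `CCOC(=O)c1cccc(-c2ccc(OCC)cc2)c1` gives 50000 nM in an assay on COS-7 cells for inhibition of patatin-like phospholipase domain-containing protein 2 (Mus musculus); on this read-out higher numbers stand for weaker inhibition and lower numbers for stronger inhibition
compound 2 `CCOC(=O)c1cccc(-c2ccc(C(C)=O)cc2)c1` gives 200000 nM in this assay

Going by the values given here, compound 1 stands at the lower of the two numbers; the only step recorded, a 4.0-fold higher number from compound 1 to compound 2 (0.60 log units; beyond the scatter), concerns the aromatic substituent. Compound 3 `CCCCCCOC(=O)c1cccc(-c2ccc(OCC)cc2)c1` differs from compound 1 by butyl in place of hydrogen on a saturated chain carbon, two bonds along the chain from an oxygen next to a carbonyl group. No measured step touches the ester chain, so nothing shown bears directly on this change, and the sole step available, that from compound 1 to compound 2, informs it only as a measure of how far a single change has moved the numbers here. The step is therefore expected to be a 1.3-fold lower number from compound 1 to compound 3 (0.10 log units; within the scatter), with wide uncertainty. Compound 3 is estimated at 40000 nM, within 10000 nM to 150000 nM.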

Compound 3, half-maximal inhibitory concentration: > 200000 nM
Compound 3 ended at the assay's limit; the forecaster's own chance of this, stated with the estimate: 30%; middle value at least 5.0-fold (0.69 log units) from the limit.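

Going by these compounds alone, the ester chain responds to change, which the earlier compounds could not show: butyl in place of hydrogen on this saturated chain carbon gives an at least 4.0-fold higher number from compound 1 to compound 3 (0.60 log units; beyond the scatter). In this assay compound 3 gives > 200000 nM, which is a limit of the assay and not a number. Going from ethyl to hexyl at this position therefore does not lower the number, and the step has only a lower bound.

From the compounds shown here alone, the true size of the step remains open. Also open, going by these compounds, is whether a shorter chain, an amine at the chain end or a carboxylic acid in place of the ester would keep or lower the number of compound 1.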